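The source may report more compounds than this note shows. Statements on the series, on what has been measured and on what is new or still open speak of the compounds shown alone.

In a functional assay on NCI/ADR-RES cells (Homo sapiens) for inhibition (on this read-out lower numbers stand for stronger inhibition of growth and higher numbers for weaker inhibition of growth), compound 1 `O=S(=O)(/C=C/c1ccccc1)Cc1ccc(Nc2ncnc3ccccc23)cc1` gives > 100000 nM, which is a limit of the assay and not a number. Compound 3 `CC(C)(C)c1cc(/C=C/S(=O)(=O)Cc2ccc(Nc3ncnc4ccccc34)cc2)cc(C(C)(C)C)c1O` gives > 100000 nM, also only a limit. For the measured compounds named here, compound 2 `O=S(=O)(/C=C/c1ccc(Cl)c(Cl)c1)Cc1ccc(Nc2ncnc3ccccc23)cc1` gives 22000 nM, the only actual number here. The other two compounds both stand at the limit of > 100000 nM in this assay, at which 2 of the 3 values shown sit.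

Compound 4 `O=S(=O)(/C=C/c1ccc(Cl)cc1)Cc1ccc(Nc2ncnc3ccccc23)cc1` has hydrogen in place of chloro on an aromatic carbon of compound 2, turning 3,4-dichlorophenyl into 4-chlorophenyl: hydrogen in place of chloro on an aromatic carbon.

Going by the values given here, the one measured step that bears on this is an at least 4.5-fold lower number from compound 1 to compound 2 (0.65 log units; beyond the scatter), where 3,4-dichlorophenyl replaced phenyl. Compound 4 keeps only part of that change, so a partial return towards weaker inhibition is expected. The expected step is a 2.3-fold higher number from compound 2 to compound 4 (0.36 log units; beyond the scatter). For compound 4 the estimated value is 50000 nM, with an expected range of 20000 nM to 100000 nM.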

Compound 4, concentration for 50% growth inhibition: > 100000 nM
Compound 4 ended at the assay's limit; the forecaster's own chance of this, stated with the estimate: 35%; middle value at least 2.0-fold (0.30 log units) away from the limit.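

In this assay, for the compounds shown here, cutting 3,4-dichlorophenyl back to 4-chlorophenyl gives an at least 4.5-fold higher number from compound 2 to compound 4 (0.65 log units; beyond the scatter), so the single chloro group left in compound 4 does not keep the measurable inhibition of compound 2. Compound 4 gives > 100000 nM, which is a limit of the assay and not a number. The chloro group that leaves, ortho to a chloro group, therefore counts among these compounds, and compound 4 joins the others at the limit: the limit of > 100000 nM in this assay, at which 3 of the 4 values shown sit.

Going by these compounds, the step between compound 1 and compound 4 cannot be read, so whether the remaining chloro group contributes anything stays open. Also open, on these data alone, is whether a bromo or methoxy group could stand in for the lost chloro.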